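The source may hold more compounds than are shown below. What is called first, only, known or untested is meant among the compounds shown, and "the series" means these compounds.

Measured compounds:
compound 1 `CN(C(=O)C(C)(C)C)c1ccc2[nH]c(-c3n[nH]c4ccccc34)cc2n1` — 22200 nM
compound 2 `CN(C(=O)CCc1ccccc1)c1ccc2[nH]c(-c3n[nH]c4ccccc34)cc2n1` — 20900 nM
compound 3 `Cc1ccc(S(=O)(=O)N(C)c2ccc3[nH]c(-c4n[nH]c5ccccc45)cc3n2)cc1` — 16300 nM

All three share one core and differ only in the group carried on the methylated nitrogen. In a functional assay on SMMC-7721 cells (Homo sapiens) for antiproliferative activity, read by MTT assay, with a stated time of 72 h (on this read-out higher numbers stand for weaker inhibition and lower numbers for stronger inhibition), compound 1 gives 22200 nM and compound 2 gives 20900 nM; the step of a 1.1-fold lower number from compound 1 to compound 2 (0.03 log units; within the scatter) does not separate them. Compound 3 gives 16300 nM in this assay, and the steps of a 1.4-fold lower number from compound 1 to compound 3 (0.13 log units; within the scatter) and a 1.3-fold lower number from compound 2 to compound 3 (0.11 log units; within the scatter) both stay within the scatter, so none of the three compounds can be told apart on these numbers.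

Compound 4 `COc1ccc(S(=O)(=O)N(C)c2ccc3[nH]c(-c4n[nH]c5ccccc45)cc3n2)c(OC)c1` keeps the sulfonamide of compound 3 and changes only the aryl group on the sulfur: 2,4-dimethoxyphenyl in place of 4-methylphenyl on a sulfonyl sulfur. Within the data shown here, no measured step alters this aryl group, so the bearing of the data on this change is indirect. The steps that do exist, from acyl to sulfonyl and between the two acyl groups, all lie within the scatter, and the series as a whole spans a narrow band.

On that basis compound 4 is expected to show a step of a 1.1-fold lower number from compound 3 to compound 4 (0.04 log units; within the scatter) that stays within the scatter, in no clear direction. The estimate for compound 4 in this assay is 15000 nM, with a range from 5000 nM to 45000 nM.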

Compound 4, half-maximal inhibitory concentration: 10800 nM
Beside the measured number, compound 4's estimate is 1.4-fold (0.14 log units) above it; low and high end bracket the measured number.
By their numbers in this assay, from the lowest: compounds 4, 3, 2 and 1 (each within the scatter of the next, the first and the last beyond it).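

In this assay, among these compounds, the first measured change to the aryl group on the sulfonyl sulfur, 2,4-dimethoxyphenyl in place of 4-methylphenyl, gives a 1.5-fold lower number from compound 3 to compound 4 (0.18 log units; within the scatter), so the data do not separate these two sulfonamides. The swap does, however, extend the set to a pair that can be told apart: compound 4 gives 10800 nM and compound 1 gives 22200 nM, and these two values lie beyond the scatter of each other, although every neighbouring pair in the ordered series stays within it. Nothing available explains this small spread or ties it to any feature of the 2,4-dimethoxyphenyl group.

As far as these compounds go, it remains open whether a single methoxy group on the aryl ring would read any differently from the 2,4-dimethoxyphenyl group, and whether an amine or a carboxylic acid on that ring would move the number beyond the scatter of compound 3. Also open, from the compounds shown here alone, is what a hydrogen in place of the methyl on the sulfonamide nitrogen would do.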